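The source may hold more compounds than are shown below. What is called first, only, known or untested is meant among the compounds shown, and "the series" means these compounds.

Compound 1 `Cc1nc(S(C)(=O)=O)ccc1Oc1ncnc(OC2CCN(C(=O)O[C@@H](C)C(F)(F)F)CC2)c1F` is the reference point of this small set. For the measured compounds named here, in a functional assay on isolated protein for inhibition of Glucose-dependent insulinotropic receptor (Homo sapiens), read by HTRF and cAMP accumulation (on this read-out higher numbers stand for an effect only at larger amounts of compound and lower numbers for an effect already at smaller amounts), compound 1 gives 9.86 nM, which is the lowest of the two numbers measured; its only neighbour is compound 2 `Cc1nc(S(C)(=O)=O)ccc1Oc1ncnc(OC2CCN(C(=O)C3CCCC3)CC2)c1F`, which in this assay gives 72.8 nM. Going by the values given here, the one measured step, a 7.4-fold higher number from compound 1 to compound 2 (0.87 log units; beyond the scatter), is the sole guide to what the carbonyl carbon tolerates: trading the 1-(trifluoromethyl)ethoxy group for cyclopentyl costs a modest amount, beyond the scatter.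

Compound 3 `Cc1nc(S(C)(=O)=O)ccc1Oc1ncnc(OC2CCN(C(=O)c3noc(C(C)(C)F)n3)CC2)c1F` changes the same position of compound 1 in a different way: a group of 9 heavy atoms (5 carbon, 2 nitrogen, 1 oxygen, 1 fluorine; one five-membered aromatic ring with 3 hetero atoms) in place of a group of 7 heavy atoms (3 carbon, 1 oxygen, 3 fluorine; no ring), on a carbonyl carbon. Among the compounds with values here, the measured step from compound 1 to compound 2 bears on this only loosely, since a five-membered aromatic ring with 3 hetero atoms enters rather than a carbocycle, and no measured compound carries such a ring. Because of a 7.4-fold higher number from compound 1 to compound 2 (0.87 log units; beyond the scatter), a weakening of similar or somewhat smaller size is expected, so the step of a 3.0-fold higher number from compound 1 to compound 3 (0.48 log units; beyond the scatter) is estimated to lie in the same direction. Compound 3 is therefore expected to give about 30 nM in this assay, with a plausible range from 8 nM to 120 nM.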

Compound 3, half-maximal effective concentration: 14 nM
The estimate for compound 3 lay 2.1-fold (0.33 log units) above the measured number; measured number inside the range.
By their numbers in this assay, from the lowest: compounds 1 and 3 (each within the scatter of the next); then compound 2.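

In this assay, the carbonyl carbon bonded to the amide-type nitrogen in a ring accepts a group with a five-membered aromatic ring with 3 hetero atoms without any reading beyond the scatter relative to 1-(trifluoromethyl)ethoxy (a 1.4-fold higher number from compound 1 to compound 3 (0.15 log units; within the scatter)), even though the entering group has no defined stereocentre. Carrying a five-membered ring on this carbon therefore does not by itself go with the higher number of compound 2, as the step between the two ring-bearing groups lies beyond the scatter (a 5.2-fold lower number from compound 2 to compound 3 (0.72 log units; beyond the scatter)). Nothing available here accounts for these differences.

Going by these compounds, whether the advantage over cyclopentyl rests on the aromatic ring with its hetero atoms or on the fluorine-bearing carbon attached to that ring stays open, since these features enter together in compound 3. The compounds shown also leave open how this position would respond to a phenyl ring, an amine, a carboxylic acid or a longer carbon chain on the same carbonyl carbon.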